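Swapping the halophenyl group on a methylated core

The source may hold more compounds than are shown below. What is called first, only, known or untested is meant among the compounds shown, and "the series" means these compounds.

Compound 1, `O=C(Nc1ccc(Oc2ccnc3[nH]ccc23)cc1)c1cc2cccnc2n(-c2ccc(F)c(Cl)c2)c1=O`, gives 560 nM in a functional assay on HT-29 cells (Homo sapiens) for antiproliferative activity, read by MTT assay, with a stated time of 72 h; a higher number here means a weaker inhibitor, a lower number a stronger inhibitor.
Compound 2, `O=C(Nc1ccc(Oc2ccnc3[nH]ccc23)cc1)c1cc2cccnc2n(-c2ccc(Br)cc2F)c1=O`, gives 2360 nM in this assay.
Compound 3, `Cn1ccc2c(Oc3ccc(NC(=O)c4cc5cccnc5n(-c5ccc(F)c(Cl)c5)c4=O)cc3)ccnc21`, gives 1210 nM in this assay.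

Compound 2 differs from compound 1 by 4-bromo-2-fluorophenyl in place of 3-chloro-4-fluorophenyl on an aromatic nitrogen, and this brought a 4.2-fold higher number from compound 1 to compound 2 (0.62 log units; beyond the scatter). Compound 3 differs from compound 1 by methyl in place of hydrogen on an aromatic nitrogen, which brought a 2.2-fold higher number from compound 1 to compound 3 (0.33 log units; beyond the scatter). The values of compound 2 and compound 3 lie within the usual scatter of each other, so nothing separates them.

Compound 4, `Cn1ccc2c(Oc3ccc(NC(=O)c4cc5cccnc5n(-c5ccc(Br)cc5F)c4=O)cc3)ccnc21`, has not yet been measured. It differs from compound 3 by 4-bromo-2-fluorophenyl in place of 3-chloro-4-fluorophenyl on an aromatic nitrogen, which is the same change, at the same place, as the one from compound 1 to compound 2; only the cores differ, as described above. The step from compound 3 to compound 4 is expected to be a 3.7-fold higher number from compound 3 to compound 4 (0.57 log units; beyond the scatter), near the earlier one, because the same change gave a 4.2-fold higher number from compound 1 to compound 2 (0.62 log units; beyond the scatter). Whether it carries over onto the methylated core rests on one example only. Compound 4 is therefore estimated at 4500 nM, between 1800 nM and 12000 nM.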

Compound 4, half-maximal inhibitory concentration: 2580 nM
The estimate for compound 4 lay 1.7-fold (0.24 log units) above the measured number; measured number inside the range.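

In this assay the change from 3-chloro-4-fluorophenyl to 4-bromo-2-fluorophenyl on the methylated core gave a 2.1-fold higher number from compound 3 to compound 4 (0.33 log units; beyond the scatter) and so went the same way as on the core of compound 1, with no clear difference in size between the two steps: the same change on two cores in this assay, a 4.2-fold higher number (0.62 log units; beyond the scatter) from compound 1 to compound 2 and a 2.1-fold higher number (0.33 log units; beyond the scatter) from compound 3 to compound 4, 2.0-fold (0.30 log units) apart, within the scatter of two such steps. Methyl in place of hydrogen on the aromatic nitrogen gave a 1.1-fold higher number from compound 2 to compound 4 (0.04 log units; within the scatter) and this step likewise cannot be told apart from its earlier counterpart: the same change on two cores in this assay, a 2.2-fold higher number (0.33 log units; beyond the scatter) from compound 1 to compound 3 and a 1.1-fold higher number (0.04 log units; within the scatter) from compound 2 to compound 4, 2.0-fold (0.30 log units) apart, within the scatter of two such steps. Within these four compounds, each change therefore carries over from one core to the other as far as can be seen, but each comparison rests on only two steps in one assay and does not show that the steps are equal in size or that other groups would behave alike.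

The compounds shown leave open whether other groups on the same nitrogen, such as unsubstituted phenyl or 4-methoxyphenyl, would follow the same course on both cores. They also leave open what a longer chain, such as ethyl or 2-methoxyethyl, would do in place of methyl.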